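A few compounds are considered here, and "the series" means these few. Any claim that something is new, unique, unknown or untested is made for them only; others in the source may bear on it.

Measured compounds:
- compound 1, `Cc1cc(=O)oc2cc(OCc3nc(N)nc(Nc4ccc(Cl)cc4)n3)ccc12`: 32500 nM in an assay on COS-7 cells for agonist activity at Free fatty acid receptor 1 (Homo sapiens), read by scintillation counting and inositol phosphate accumulation, with a stated time of 90 min; on this read-out higher numbers stand for an effect only at larger amounts of compound and lower numbers for an effect already at smaller amounts
- compound 2, `Cc1ccc(Nc2nc(N)nc(COc3ccc4c(C)cc(=O)oc4c3)n2)cc1`: in this assay compound 2 gives 1790 nM
- compound 3, `Cc1ccc(Nc2nc(N)nc(COc3cc(N4CCCC4=O)ccc3Cl)n2)cc1Cl`: in this assay compound 3 gives "not determined" (no result reported)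

Compound 1 and compound 2 share a core and differ in one place: methyl in place of chloro on an aromatic carbon. This change gave an 18-fold lower number from compound 1 to compound 2 (1.26 log units; beyond the scatter).

Compound 3 carries a different core, and how it differs from the core of compound 1 is not broken down here. Compound 4, `Cc1ccc(Nc2nc(N)nc(COc3cc(N4CCCC4=O)ccc3C)n2)cc1Cl`, is not yet measured; it differs from compound 3 by methyl in place of chloro on an aromatic carbon. The group that leaves and the group that enters are the same as from compound 1 to compound 2, but the surroundings are not: in compound 1 the place is para to a large group, while in compound 3 it is ortho to a large group and para to a 2-oxopyrrolidin-1-yl group. So this is the same kind of change, not the same change.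

Among the compounds with values here, since compound 3 has no number, no size of step can be given for it. For compound 4 the expectation rests on compound 2, whose 1790 nM shows what a methyl-bearing compound of this family can reach, and is estimated at 2500 nM, between 300 nM and 20000 nM.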

Compound 4, half-maximal effective concentration: 7450 nM
For compound 4 the middle estimate is 3.0-fold (0.47 log units) below the measured one, and the stated range covers the measured number.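

Compound 3 has no number in this assay, and without one the step to compound 4 , which gives 7450 nM, cannot be read. No measured evidence bears on this result. Still open, on these data alone, is whether methyl in place of chloro at this place lowers the number as it did from compound 1 to compound 2.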